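This account rests on a few compounds, and the source may have more. Where it says the series, first, only, none or still open, it means among the compounds named here.

In a functional assay on the whole organism for inhibition, with Rattus norvegicus as the target, read by paw edema (on this read-out higher numbers stand for an effect only at larger amounts of compound and lower numbers for an effect already at smaller amounts), compound 1 `O=C(O)c1cc(-c2ncco2)ccc1O` gives 100 mg/kg and compound 2 `O=C(O)c1cc(-c2cscn2)ccc1O` gives 95 mg/kg. These two numbers lie within the usual scatter of each other, so compound 2 stands level with compound 1 and the pair cannot be ranked. Compound 3 `O=C(O)c1cc(-c2nccs2)ccc1O` has the same atoms as compound 2, joined differently: 1,3-thiazol-2-yl in place of 1,3-thiazol-4-yl on an aromatic carbon. It carries 1,3-thiazol-2-yl in place of 1,3-thiazol-4-yl on the aromatic carbon meta to the carboxy group and para to the hydroxy group. For the measured compounds named here, the only measured step that bears on this is a 1.1-fold lower number from compound 1 to compound 2 (0.02 log units; within the scatter), also a change of the group on that aromatic carbon, and it stays within the scatter. One step is thin evidence, but the expected step in this assay, no change at the digits printed from compound 2 to compound 3 (within the scatter), likewise stays within the scatter, with no clear direction. For compound 3 the estimated value is 95 mg/kg, with an expected range from 55 mg/kg to 160 mg/kg.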

Compound 3, dose for half-maximal effect: > 250 mg/kg
Compound 3: only a limit was reported; the forecaster's own chance of this, stated with the estimate: 10%; middle value at least 2.6-fold (0.42 log units) away from the limit.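

In this assay, this position proves sensitive to how the five-membered ring is attached, which the earlier step could not show: 1,3-thiazol-2-yl in place of 1,3-thiazol-4-yl, with the same atoms joined differently, gives an at least 2.6-fold higher number from compound 2 to compound 3 (0.42 log units; beyond the scatter). 1,3-thiazol-2-yl in place of 1,3-oxazol-2-yl gives an at least 2.5-fold higher number from compound 1 to compound 3 (0.39 log units; beyond the scatter), so the change is beyond the scatter against both earlier compounds. The value of compound 3 is a limit and not a number: the limit of > 250 mg/kg in this assay, at which 1 of the 3 values shown sits.

The full size of both steps therefore stays open, and the compounds shown do not say why the point of attachment matters. Also open, going by these compounds, is how this aromatic carbon would respond to a group of another kind, such as an amine or a longer chain.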